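Compound 1 and the Hydroxy to Trifluoromethyl Exchange

The compounds below may be only part of what the source reports. "The series", "measured", "known", "first", "only" and "open" are said of these compounds alone.

Compound 1 `O=C(Nc1cccc(O)c1)C1c2ccccc2CCN1C(=O)c1ccc(Cl)cc1` was tested in a functional assay on NUGC-3 cells (Homo sapiens) for inhibition, read by sulforhodamine B assay, with a stated time of 48 h; a lower number here means a stronger inhibitor of growth, a higher number a weaker inhibitor of growth. In this assay compound 1 gives > 10000 nM, which is a limit of the assay and not a number. Compound 2 `O=C(Nc1cccc(O)c1)C1NCCc2ccccc21` keeps hydrogen in place of the (4-chlorophenyl)carbonyl on an amine nitrogen in a ring. In this assay compound 2 gives > 10000 nM, again a limit. Compound 3 `COc1ccc(NC(=O)C2NCCc3ccccc32)cc1` is the third measured member of the set. In this assay compound 3 gives > 10000 nM, also a limit. The step that the two limits leave unreadable from compound 1 to compound 2 therefore cannot be read, and every measured value in the set sits at the limit of > 10000 nM in this assay, at which 3 of the 3 values shown sit.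

Compound 4 `O=C(Nc1cccc(C(F)(F)F)c1)C1c2ccccc2CCN1C(=O)c1ccc(Cl)cc1` has not yet been measured. It differs from compound 1 by trifluoromethyl in place of hydroxy on an aromatic carbon. Among the compounds with values here, no measured step touches this part of the molecule, as the only step in the set changes the amine nitrogen in a ring, and all three measured values are limits rather than numbers. The data thus give no basis for expecting a step in this assay in either direction beyond the scatter, and compound 4 is expected to stand close to where compound 1 stands. Compound 4 is accordingly estimated at 8000 nM, with a range from 1500 nM to 30000 nM, which means an expected step of an at least 1.2-fold lower number from compound 1 to compound 4 (0.09 log units; that floor lies within the scatter).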

Compound 4, concentration for 50% growth inhibition: > 10000 nM
Compound 4 gave a limit, no number; the forecaster's own chance of this, stated with the estimate: 60%; middle value at least 1.2-fold (0.09 log units) away from the limit.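

In this assay compound 4 gives > 10000 nM, which is a limit of the assay and not a number. As compound 1 also stands at a limit, no step can be read between compound 1 and compound 4. The compounds shown leave open whether trifluoromethyl in place of hydroxy alters growth inhibition at all, and how any of these compounds ranks, as all results stand at one limit: the limit of > 10000 nM in this assay, at which 4 of the 4 values shown sit.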